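A Chlorine Added to the Phenyl of Compound 1

The compounds below may be only part of what the source reports. "The series", "measured", "known", "first", "only" and "open" are said of these compounds alone.

Compound 1 `Cc1cc(O)c(C(C)C)cc1-c1cc(-c2ccccc2)c(C#N)c(=O)[nH]1` is the plainest of three close relatives that share one core and differ only in the aromatic group attached to it. In a functional assay for inhibition, tested at 100 ug/mL (on this read-out higher numbers stand for a stronger effect at the one concentration tested and lower numbers for a weaker effect), compound 1 gives 41%, the lowest of the three numbers. Compound 2 `Cc1cc(O)c(C(C)C)cc1-c1cc(-c2cccs2)c(C#N)c(=O)[nH]1` gives 68% in this assay, and compound 3 `COc1ccc(-c2cc(-c3cc(C(C)C)c(O)cc3C)[nH]c(=O)c2C#N)cc1OC` gives 61%; the step of a number 27 percentage points higher from compound 1 to compound 2 (beyond the scatter) and the step of a number 20 percentage points higher from compound 1 to compound 3 (beyond the scatter) both lie beyond the scatter, while a number 7 percentage points lower from compound 2 to compound 3 (within the scatter) does not.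

Compound 4 `Cc1cc(O)c(C(C)C)cc1-c1cc(-c2ccccc2Cl)c(C#N)c(=O)[nH]1` keeps the phenyl of compound 1 and adds one atom to it: chloro in place of hydrogen on an aromatic carbon. The two measured steps out of compound 1 each exchange the whole phenyl for a different ring, so neither shows what a single chloro on that ring does; they show only that compound 1 is not the ceiling among these compounds. Among the measured compounds shown here, with no measured step of the same kind, the expectation for compound 4 is a modest rise at most, with a number 9 percentage points higher from compound 1 to compound 4 (within the scatter) as the expected step. Compound 4 is therefore estimated at 50% in this assay, within a range from 30% to 75%.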

Compound 4, a percentage reported as inhibition, at one concentration (the size of the read-out at that concentration, not a potency): 34%
Compound 4: middle estimate off by 16 percentage points, on the high side, within the range that was stated.
By their numbers in this assay, from the lowest: compounds 4 and 1 (each within the scatter of the next); then compounds 3 and 2 (each within the scatter of the next).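

In this assay, chloro in place of hydrogen, ortho to a large group on the phenyl, gives a number 7 percentage points lower from compound 1 to compound 4 (within the scatter), so this one atom does not separate the two compounds. Exchanging the whole ring is a different matter: the 2-chlorophenyl ring stays with the plain phenyl and apart from the other two rings, with a number 27 percentage points lower from compound 3 to compound 4 (beyond the scatter) and a number 34 percentage points lower from compound 2 to compound 4 (beyond the scatter), which means that the higher numbers of those two compounds are not matched by adding a chloro to the phenyl. Nothing shown here gives a reason for these numbers.

On these data alone, whether a chloro on another carbon of the phenyl would read the same remains open, as does the effect of an amine or a carboxylic acid at this ortho place. Also open, as far as these compounds go, is which feature of the thiophen-2-yl and 3,4-dimethoxyphenyl rings goes with their higher numbers.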